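This account rests on a few compounds, and the source may have more. Where it says the series, first, only, none or still open, it means among the compounds named here.

In a functional assay on HepG2 cells (Homo sapiens) for cytotoxicity, read by MTT assay, with a stated time of 72 h (on this read-out higher numbers stand for weaker inhibition and lower numbers for stronger inhibition), this set mostly returns limits rather than numbers. Compound 1 `N#Cc1cnn(-c2ccc(S(N)(=O)=O)cc2)c1N` gives > 100000 nM, which is a limit of the assay and not a number. Compound 2 `NC(=O)c1cnn(-c2ccc(S(N)(=O)=O)cc2)c1N` gives > 100000 nM, likewise a limit. The step that the two limits leave unreadable from compound 1 to compound 2 therefore cannot be read in size or direction; the limit of > 100000 nM in this assay, at which 2 of the 3 values shown sit, covers both of its ends. Among the compounds with values here, compound 3 `NS(=O)(=O)c1ccc(-n2ncc3c(=O)[nH]c(-c4ccc(Cl)cc4)nc32)cc1` is the only member with a measured number and gives 23900 nM. Since the other two values are not numbers, no ordering within the set can be drawn from them.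

Compound 4 `COc1ccc(-c2nc3c(cnn3-c3ccc(S(N)(=O)=O)cc3)c(=O)[nH]2)cc1` differs from compound 3 by methoxy in place of chloro on an aromatic carbon. Within the data shown here, no measured step in the set covers a change of this kind: the one step between measured compounds concerns a different position and is itself unreadable. The expectation for compound 4 rests on compound 3 alone at 23900 nM. The step of a 1.3-fold higher number from compound 3 to compound 4 (0.10 log units; within the scatter) is estimated to stay within the usual scatter, with no direction preferred. Compound 4 is thus expected at 30000 nM, within 10000 nM to 100000 nM, with a fair chance that only a limit is returned.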

Compound 4, half-maximal inhibitory concentration: > 100000 nM
Compound 4 was reported as a limit; the forecaster's own chance of this, stated with the estimate: 25%; middle value at least 3.3-fold (0.52 log units) away from the limit.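

In this assay, within the data shown here, the change from 4-chlorophenyl to 4-methoxyphenyl gives the first readable step, an at least 4.1-fold higher number from compound 3 to compound 4 (0.62 log units; beyond the scatter) and so shows that the group on this aromatic carbon can move the read-out. Compound 4 gives > 100000 nM as a limit of the assay and not a number, so the step has a lower bound but no upper one. Among these compounds, the only number in the set still belongs to compound 3, and the other compounds sit at one limit: the limit of > 100000 nM in this assay, at which 3 of the 4 values shown sit.

From the compounds shown here alone, with only chloro and methoxy compared at this place, whether a fluoro, a methyl or an amine there would return a number in this assay remains open. Going by these compounds, the step between the two compounds at the limit cannot be read, so changes elsewhere on the shared core also remain open.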